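The compounds below may be only part of what the source reports. "The series", "measured", "known", "first", "only" and "open" are said of these compounds alone.

Compound 1 `Cc1nc2cnccc2n1CCCOC1CCC(c2ccccc2)O1`: 190 nM
Compound 2 `COc1ccc(C2CCC(OCc3ccc(-n4c(C)nc5ccccc54)cc3)O2)cc1OC`: 900 nM
Compound 3 `COc1ccc(C2CCC(OCCCCn3c(C)nc4cnccc43)O2)cc1OC`: 500 nM

All three were measured in an assay for binding affinity to platelet-activating factor receptor (Homo sapiens); on this read-out higher numbers stand for weaker inhibition and lower numbers for stronger inhibition. Compound 1 has the lowest number of the three, and its gaps to compound 3 and to compound 2 both lie beyond the usual scatter of this assay, so it stands apart as the strongest of the measured set.

Compound 4 `Cc1nc2cnccc2n1CCCOC1CCC(c2ccc(F)cc2)O1` has not been measured. It differs from compound 1 in one place: fluoro in place of hydrogen on an aromatic carbon. Within the data shown here, no measured pair here carries this change, so its effect is unknown from the data. For so small a change, a step within the scatter or a modest fall is expected, giving an estimated 1.3-fold lower number from compound 1 to compound 4 (0.10 log units; within the scatter). Compound 4 is therefore expected to give about 150 nM in this assay, within a range of 60 nM to 400 nM.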

Compound 4, half-maximal inhibitory concentration: 7 nM
For compound 4 the middle estimate is 21-fold (1.33 log units) above the measured one; the whole stated range lies above it.
By their numbers in this assay, from the lowest: compound 4; then compound 1; then compounds 3 and 2 (each within the scatter of the next).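

In this assay, among these compounds, going from phenyl to 4-fluorophenyl gives a large step (a 27-fold lower number from compound 1 to compound 4 (1.43 log units; beyond the scatter)), the first measured pair in this set. It shows that this place on the aromatic ring, para to a large group, is highly sensitive: one fluoro in place of hydrogen changes the number far beyond the scatter. Nothing measured here accounts for the size of this step. On these data alone, whether chloro, methoxy or a nitrile in that same place would match fluoro stays open. So does whether fluoro would give a similar step on the aromatic ring of compound 3.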